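Straightening the hydroxy chain on the amide nitrogen

A few compounds are considered here, and "the series" means these few. Any claim that something is new, unique, unknown or untested is made for them only; others in the source may bear on it.

Three compounds sharing one core were measured in an assay on HEK293 cells for displacement of a labelled ligand from adenosine receptor A2b (Homo sapiens), read by scintillation counting, with a stated time of 30 min, tested at 10 uM; on this read-out lower numbers stand for less inhibition and higher numbers for more inhibition at the one concentration tested (going by the name of the read-out). Compound 1 `N=c1oc2ccc(Br)cc2cc1C(=O)NC1CCCCC1` gives 10%, compound 2 `COc1cc(Br)cc2cc(C(=O)NCCCO)c(=N)oc12` gives 30%, and compound 3 `CCC(CO)NC(=O)c1cc2cc(Br)ccc2oc1=N` gives 4%. Among the compounds with values here, compound 3 thus stands lowest, with compound 1 nearest and compound 2 furthest; the only step between neighbours differing in one place, a number 6 percentage points lower from compound 1 to compound 3 (within the scatter), lies within the scatter. Compound 4 `N=c1oc2ccc(Br)cc2cc1C(=O)NCCCO` differs from compound 3 by 3-hydroxypropyl in place of 1-(hydroxymethyl)propyl on an amide-type nitrogen. Within the data shown here, compound 2 carries the same 3-hydroxypropyl group together with a further methoxy group, and its value is higher than that of compound 3, but no single-change step links it to compound 4. Given that the one amide-nitrogen step was within the scatter, compound 4 is expected to show a number 8 percentage points higher from compound 3 to compound 4 (within the scatter), an estimate of 12% within 0% to 30%.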

Compound 4, a percentage reported as inhibition, at one concentration (the size of the read-out at that concentration, not a potency): 25%
The estimate for compound 4 lay 13 percentage points below the measured number; low and high end bracket the measured number.
By their numbers in this assay, from the lowest: compounds 3 and 1 (each within the scatter of the next); then compounds 4 and 2 (each within the scatter of the next).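

In this assay the substituent on the amide-type nitrogen now shows steps beyond the scatter: 3-hydroxypropyl in place of 1-(hydroxymethyl)propyl gives a number 21 percentage points higher from compound 3 to compound 4 (beyond the scatter) and the same group in place of cyclohexyl gives a number 15 percentage points higher from compound 1 to compound 4 (beyond the scatter) on the shared core. Hydrogen in place of methoxy on an aromatic carbon gives a number 5 percentage points lower from compound 2 to compound 4 (within the scatter) and so leaves the value of the 3-hydroxypropyl compounds unchanged within the scatter. Nothing measured here accounts for the difference between the two hydroxy chains. As far as these compounds go, whether a longer hydroxy chain, or an amine in place of the hydroxy group, would give a higher number remains open.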